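Oxazole for phenyl on the piperidine amide: lipophilicity note

The source may report more compounds than this note shows. Statements on the series, on what has been measured and on what is new or still open speak of the compounds shown alone.

For the measured compounds named here, compound 1 `O=C(c1ccccc1)N1CCC(C(=O)N2N=CCC2c2ccccc2)CC1` is the lower of the two measured members in a physicochemical assay for lipophilicity, read by HPLC, measured as chromatographic lipophilicity, at pH 7.4 (on this read-out higher numbers stand for higher lipophilicity and lower numbers for lower lipophilicity), where compound 1 gives 4.4. Going by the values given here, compound 2 `CC(C)(C)C(=O)N1N=CCC1c1cccc(F)c1` is the only other measured compound; in this assay compound 2 gives 5.9, a number that lies beyond the scatter above compound 1. Among the compounds with values here, no single-point step between measured compounds is available, so the two values only bracket where the series has sat so far.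

Compound 3 `O=C(c1cocn1)N1CCC(C(=O)N2N=CCC2c2ccccc2)CC1` differs from compound 1 in one place: 1,3-oxazol-4-yl in place of phenyl on a carbonyl carbon. The incoming ring is smaller and carries hetero atoms and hydrogen-bond acceptors where the outgoing one carries none, as the counted difference shows. On that basis the step from compound 1 to compound 3 is expected to be a decrease in this assay that is clearly beyond the scatter, of about a number 1.20 log units lower from compound 1 to compound 3 (beyond the scatter). Starting from compound 1 at 4.4, compound 3 is therefore estimated at 3.2, with a range from 2.6 to 3.8.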

Compound 3, distribution coefficient: 2.9
The estimate for compound 3 lay 0.30 log units above the measured number, within the range that was stated.
By their numbers in this assay, from the lowest: compound 3; then compound 1; then compound 2.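

For the compounds shown here, replacing phenyl with 1,3-oxazol-4-yl on a carbonyl carbon gives the first one-place comparison: in this assay the read-out moves a number 1.50 log units lower from compound 1 to compound 3 (beyond the scatter) and the step is large. This position therefore has a strong hold on the read-out, since the rest of the core of compound 1 stays unchanged across the pair and the whole step belongs to this one exchange of rings. The earlier pair of compound 1 and compound 2 could only bracket the series and could not tie any part of a difference to this place. No supporting data bear on why the step has this size.

Going by these compounds alone, the single step leaves open how much of it goes with the smaller five-membered ring and how much with the hetero atoms and hydrogen-bond acceptors, since these change together here; a pyridin-3-yl or a thiophen-2-yl ring on the same carbonyl carbon would pull those apart. Also open, on these data alone, is how the read-out responds to a substituted oxazole, such as one bearing a methyl group or a dimethylamino group, at this same position.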